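Removing a Propyl Group From Three Inactive Compounds

A few compounds are considered here, and "the series" means these few. Any claim that something is new, unique, unknown or untested is made for them only; others in the source may bear on it.

Compound 1 `Sc1nncc2cncn12`: > 48000 nM in a functional assay for inhibition, with Homo sapiens as the target; on this read-out lower numbers stand for stronger inhibition and higher numbers for weaker inhibition
Compound 2 `CCCc1ncn2c(S)nncc12`: > 48000 nM in this assay
Compound 3 `C=CCn1ncc2c(CCC)ncn2c1=O`: > 48000 nM in this assay

Each of these three values is a limit of the assay rather than a measured number. For compound 1 the result in this assay is only the limit > 48000 nM. For compound 2 it is likewise only the limit > 48000 nM. For compound 3 it is again only the limit > 48000 nM. This is summed up by the limit of > 48000 nM in this assay, at which 3 of the 3 values shown sit, so none of the three compounds has shown measurable inhibition.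

Compound 2 and compound 1 differ in one place, (hydrogen in place of propyl on an aromatic carbon), and the step that the two limits leave unreadable from compound 2 to compound 1 cannot be read because both ends are limits. How the core of compound 3 differs from the core of compound 2 is not broken down here.

Compound 4 `C=CCn1ncc2cncn2c1=O` has not yet been measured. It differs from compound 3 by hydrogen in place of propyl on an aromatic carbon, the same change that separates compound 2 from compound 1. Because the limit of > 48000 nM in this assay, at which 3 of the 3 values shown sit, covers every value shown, there is no readable step to build on, and the matching step for compound 2 and compound 1 gives no direction either. The most likely outcome for compound 4 in this assay is therefore expected to be another limit, with an estimated value of 100000 nM, between 48000 nM and 300000 nM, which for compound 4 means an expected step that the limit leaves unreadable from compound 3 to compound 4.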

Compound 4, half-maximal inhibitory concentration: > 48000 nM
Compound 4: no number, only a limit; the forecaster's own chance of this, stated with the estimate: 90%; the middle value does not contradict the limit.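

In this assay compound 4 gives > 48000 nM, which is a limit and not a number. Compound 3 also stands at a limit, so the step from compound 3 to compound 4, hydrogen in place of propyl, cannot be read. All the compounds share one result: the limit of > 48000 nM in this assay, at which 4 of the 4 values shown sit.

The compounds shown leave open whether propyl or hydrogen at this place changes inhibition at all.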